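Tryptamine piperidine series: variation of the amine substituent

The compounds below may be only part of what the source reports. "The series", "measured", "known", "first", "only" and "open" are said of these compounds alone.

Measured in an assay on CHO cells for agonist activity at 5-hydroxytryptamine receptor 1D (Homo sapiens), read by GTPgammaS binding; on this read-out lower numbers stand for an effect already at smaller amounts and higher numbers for an effect only at larger amounts of compound:
compound 1 `CN(Cc1cccs1)C1CCN(CCCc2c[nH]c3ccc(-n4cnnc4)cc23)CC1` gives 3.5 nM
compound 2 `O[C@@H]1Cc2ccccc2[C@H]1NC1CCN(CCCc2c[nH]c3ccc(-n4cnnc4)cc23)CC1` gives 13 nM
compound 3 `CC(=O)Nc1ccc(CNC2CCN(CCCc3c[nH]c4ccc(-n5cnnc5)cc34)CC2)cc1` gives 5 nM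

Compound 3 stands second highest of the three; its gap to compound 1 is within the scatter, its gap to compound 2 beyond it. Compound 4 `OCCC(NC1CCN(CCCc2c[nH]c3ccc(-n4cnnc4)cc23)CC1)c1ccccc1` differs from compound 3 only at the amine nitrogen: 3-hydroxy-1-phenylpropyl in place of 4-acetamidobenzyl on an amine nitrogen. Within the data shown here, two steps bear on this position: a 3.7-fold higher number from compound 1 to compound 2 (0.57 log units; beyond the scatter), where a hydroxyl-bearing group entered, and a 2.6-fold lower number from compound 2 to compound 3 (0.41 log units; beyond the scatter), where the acetamidobenzyl replaced it. Compound 4 carries a hydroxyl-bearing group again, as does compound 2 with 13 nM, and drops the acetamide; a modest rise in the number is therefore expected. For compound 4 the estimate in this assay is 10 nM, range 4 nM to 25 nM, meaning a 2.0-fold higher number from compound 3 to compound 4 (0.30 log units; within the scatter).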

Compound 4, half-maximal effective concentration: 5.1 nM
Compound 4: middle estimate off by 2.0-fold (0.29 log units), on the high side, within the range that was stated.
By their numbers in this assay, from the lowest: compounds 1, 3 and 4 (each within the scatter of the next); then compound 2.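

In this assay the acetamide of 4-acetamidobenzyl is not needed at this amine nitrogen: a 1.0-fold higher number from compound 3 to compound 4 (0.01 log units; within the scatter) shows 3-hydroxy-1-phenylpropyl matching it, so a hydroxyl-bearing group does not by itself bring the higher number of compound 2. The two hydroxyl-bearing groups are separated by a 2.5-fold lower number from compound 2 to compound 4 (0.41 log units; beyond the scatter) and (3-hydroxy-1-phenylpropyl)amino stays level with methyl((thiophen-2-yl)methyl)amino in a 1.5-fold higher number from compound 1 to compound 4 (0.16 log units; within the scatter) as well. Nothing available explains the gap between the two hydroxyl-bearing groups. Open, on these data alone, is whether an amine or a carboxylic acid in place of that hydroxyl, or a longer chain, would hold the number.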